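Chloro to methoxy on the shared core

The compounds below may be only part of what the source reports. "The series", "measured", "known", "first", "only" and "open" are said of these compounds alone.

In a functional assay on HepG2 cells (Homo sapiens) for inhibition, read by MTT assay, with a stated time of 72 h (a lower number here means a stronger inhibitor, a higher number a weaker inhibitor), compound 3 `CC(C)(C)n1cc2c(n1)C(=O)CC1(CCN(C(=O)c3cc(Cl)nc4ccccc34)CC1)O2` gives 4720 nM, the highest number of the three measured. Compound 1 `CC(C)(C)n1cc2c(n1)C(=O)CC1(CCN(C(=O)c3cc(-c4ccccc4)nc4ccccc34)CC1)O2` gives 2110 nM and compound 2 `CN(C)c1ccc(-c2cc(C(=O)N3CCC4(CC3)CC(=O)c3nn(C(C)(C)C)cc3O4)c3ccccc3n2)cc1` gives 1730 nM, and between them lies a 1.2-fold lower number from compound 1 to compound 2 (0.09 log units; within the scatter). Compound 4 `COc1cc(C(=O)N2CCC3(CC2)CC(=O)c2nn(C(C)(C)C)cc2O3)c2ccccc2n1` has methoxy in place of chloro on an aromatic carbon, next to the ring nitrogen (methoxy in place of chloro on an aromatic carbon). Within the data shown here, no measured step makes this exchange. The closest evidence comes from the same carbon: chloro in place of phenyl gave a 2.2-fold higher number from compound 1 to compound 3 (0.35 log units; beyond the scatter), and chloro in place of 4-(dimethylamino)phenyl gave a 2.7-fold higher number from compound 2 to compound 3 (0.44 log units; beyond the scatter). Both steps are modest, so only a small shift toward a lower number is expected, within the scatter: a 1.3-fold lower number from compound 3 to compound 4 (0.13 log units; within the scatter). Compound 4 is estimated at 3500 nM, with an expected range of 1700 nM to 7000 nM.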

Compound 4, half-maximal inhibitory concentration: > 10000 nM
Compound 4: no number, only a limit; the forecaster's own chance of this, stated with the estimate: 8%; at least 2.8-fold (0.45 log units) between middle value and limit.
By their numbers in this assay, from the lowest: compounds 2 and 1 (each within the scatter of the next); then compound 3. At a limit, above all of these: compound 4.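

Compound 4 has no number in this assay, only a limit: the limit of > 10000 nM in this assay, at which 1 of the 4 values shown sits. The earlier compounds shown here left chloro with the highest number at this carbon, yet methoxy goes past it, with an at least 2.1-fold higher number from compound 3 to compound 4 (0.32 log units; beyond the scatter). The distance to the aryl groups also grows, with an at least 5.7-fold higher number from compound 2 to compound 4 (0.76 log units; beyond the scatter) and an at least 4.7-fold higher number from compound 1 to compound 4 (0.67 log units; beyond the scatter), so a small exchange here can matter as much as replacing either aryl group.

From the compounds shown here alone, how far compound 4 really lies beyond its limit stays open. Also open, going by these compounds, is whether an amine or an ethoxy group on this carbon would give a measurable number in this assay.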